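The source may hold more compounds than are shown below. What is called first, only, known or untested is meant among the compounds shown, and "the series" means these compounds.

Measured compounds:
compound 1 `COc1cc(-c2cc(/C=C/C(=O)c3ccc(C)cc3)nc3cc(-c4ccccc4)nn23)cc(OC)c1OC` — 27100 nM
compound 2 `COc1cc(-c2cc(/C=C/C(=O)c3ccccc3)nc3cc(-c4ccccc4)nn23)cc(OC)c1OC` — 34300 nM

Both were run in a functional assay on DU-145 cells (Homo sapiens) for antiproliferative activity, read by MTT assay, with a stated time of 24 h; a lower number here means a stronger inhibitor, a higher number a weaker inhibitor. For the measured compounds named here, compound 2 gives the higher of the two numbers, with compound 1 as its only neighbour; the gap between them, a 1.3-fold higher number from compound 1 to compound 2 (0.10 log units; within the scatter), is within the scatter, so the two compounds cannot be ordered. That step consisted of hydrogen in place of methyl on an aromatic carbon.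

Compound 3 `COc1ccc(/C=C/C(=O)c2cc(-c3cc(OC)c(OC)c(OC)c3)n3nc(-c4ccccc4)cc3n2)cc1` has not yet been measured. It differs from compound 2 by (2-(4-methoxyphenyl)ethenyl)carbonyl in place of 2-benzoylethenyl on an aromatic carbon. Going by the values given here, the only step that bears on this change is the one between compound 1 and compound 2, also a substituent exchange on an aromatic carbon, which stayed within the scatter. A single further change of that kind is therefore not expected to move the number beyond the scatter, and the expected step is a 1.3-fold lower number from compound 2 to compound 3 (0.12 log units; within the scatter). Compound 3 is estimated at 26000 nM, with a range from 10000 nM to 65000 nM.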

Compound 3, half-maximal inhibitory concentration: 16900 nM
Estimate against measurement, compound 3: 1.5-fold (0.19 log units) above; low and high end bracket the measured number.
By their numbers in this assay, from the lowest: compounds 3, 1 and 2 (each within the scatter of the next, the first and the last beyond it).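

In this assay the series now has its first step beyond the scatter: a 2.0-fold lower number from compound 2 to compound 3 (0.31 log units; beyond the scatter) shows that exchanging 2-benzoylethenyl for (2-(4-methoxyphenyl)ethenyl)carbonyl on this aromatic carbon does move the number, though only modestly. Set against the 2-((4-methylphenyl)carbonyl)ethenyl group, the exchange gives a 1.6-fold lower number from compound 1 to compound 3 (0.21 log units; within the scatter) and so compound 3 and compound 1 cannot be ordered, which limits the shift to the comparison with compound 2. Nothing available explains the shift.

The exchange reverses the order of carbonyl and ethenyl and also brings in a methoxy group, and these compounds do not separate the two changes. Also open, from the compounds shown here alone, is how an amine or a carboxylic acid on the aromatic ring of this group would read in this assay.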